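This account rests on a few compounds, and the source may have more. Where it says the series, first, only, none or still open, it means among the compounds named here.

Compound 1 `CCCCCCCCCCCO[C@@H]1[C@@H](O)[C@H](O[C@H]2O[C@H](CN)[C@@H](O)[C@H](OCCCCCCC)[C@H]2N)[C@@H](N)C[C@H]1N` gives 82.9% in an ADME assay on J774 cells (Mus musculus) for cytotoxicity, read by MTT assay, with a stated time of 24 h, tested at 10 uM; a higher number here means a weaker effect of the compound at the concentration tested, a lower number a stronger effect. Within the data shown here, only one other compound has been measured: compound 2 `CCCCCCCO[C@@H]1[C@@H](N)[C@@H](O[C@H]2[C@H](O)[C@@H](O)[C@H](N)C[C@@H]2N)O[C@H](CN)[C@H]1O` gives 77.5% in this assay, and the step of a number 5.4 percentage points lower from compound 1 to compound 2 (within the scatter) lies within the scatter, so compound 1 cannot be ranked against it. Compound 3 `CCCCCCCCCCCO[C@@H]1[C@@H](N)[C@@H](O[C@H]2[C@H](O)[C@@H](OCCCCCCCCCCC)[C@H](N)C[C@@H]2N)O[C@H](CN)[C@H]1O` carries the change (butyl in place of hydrogen on a saturated chain carbon, seven bonds along the chain from an oxygen on a saturated carbon). Among the measured compounds shown here, the one measured step also alters a chain on an oxygen on a saturated carbon and stays within the scatter, so the step of a number 2.9 percentage points lower from compound 1 to compound 3 (within the scatter) is expected to remain within the scatter as well. Compound 3 is therefore estimated at 80% in this assay, with a range from 65% to 93%.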

Compound 3, a percentage reported as activity, at one concentration (the size of the read-out at that concentration, not a potency): 81.7%
Compound 3: the middle estimate sits 1.7 percentage points below what was measured; the range from low to high includes it.
By their numbers in this assay, from the lowest: compounds 2, 3 and 1 (each within the scatter of the next).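

With this assay as the read-out, the step is a number 1.2 percentage points lower from compound 1 to compound 3 (within the scatter). The earlier step removed a chain from an oxygen on a saturated carbon, whereas this one shows that adding butyl in place of hydrogen on a saturated chain carbon, seven bonds along the chain from that kind of oxygen, also gives no difference that can be read at this concentration. Nothing available explains this result. The compounds shown leave open whether a longer chain, or an amine or carboxylic acid at this position, would also stay within the scatter.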